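A few compounds are considered here, and "the series" means these few. Any claim that something is new, unique, unknown or untested is made for them only; others in the source may bear on it.

Working notes on the series, read in an ADME assay on MT4 cells (Homo sapiens) for cytotoxicity, read by MTT assay, with a stated time of 96 h; on this read-out lower numbers stand for higher toxicity in this test and higher numbers for lower toxicity in this test. Compound 1 (`Clc1cccc(/N=N/N2CCCC2)c1`) gives > 100000 nM in this assay, and this is a limit of the assay, not a number. Compound 3 (`CN(Cc1ccccc1)/N=N/c1ccccc1`) gives >= 100000 nM, and this too is a limit. Within the data shown here, compound 2 (`CN1CCN(/N=N/c2ccccc2)CC1`) gives 65000 nM, the only full number in the set. Compound 1 therefore has no exact position, and the comparison starts from a limit.

The next structure is compound 4 (`O=[N+]([O-])c1cccc(/N=N/N2CCCC2)c1`), which has nitro in place of chloro on an aromatic carbon, meta to a group of 7 heavy atoms: nitro in place of chloro on an aromatic carbon. The core of compound 1 is otherwise kept.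

Among the measured compounds shown here, no measured pair in the set differs in one place, so the size of this change in this assay has no direct precedent here. A modest move toward lower numbers is expected, and a result still at the limit would be no surprise. That expectation is weak and rests on the shared triazene-like linkage, because compound 2 gives 65000 nM and shows that a number can be reached in this series. The estimated step of an at least 1.4-fold lower number from compound 1 to compound 4 (0.15 log units; that floor lies within the scatter) is expected to be small.

Compound 4 is estimated at 70000 nM, with an expected range of 20000 nM to 150000 nM.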

Compound 4, half-maximal cytotoxic concentration: 66000 nM
Beside the measured number, compound 4's estimate is 1.1-fold (0.03 log units) above it; the measured number falls inside the stated range.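

In this assay, among these compounds, nitro in place of chloro on an aromatic carbon gives an at least 1.5-fold lower number from compound 1 to compound 4 (0.18 log units; that floor lies within the scatter), the first step that can be read between two compounds differing in one place. With nitro at this place, meta to a group of 7 heavy atoms, the core of compound 1 yields a full number, which chloro at the same place does not provide. The step remains a floor and cannot be read as an exact size, because compound 1 stands at a limit of the assay: the limit of > 100000 nM in this assay, at which 1 of the 4 values shown sits.

The compounds shown hold only chloro and nitro at this aromatic carbon, so it remains open how an amine, a carboxylic acid or a longer chain at the same place would read, and whether any of them would give a step beyond the scatter. Also open, going by these compounds, is whether nitro on another carbon of the aromatic ring, or with a ring other than the one on the nitrogen end of the core of compound 1, would give a full number of the same order.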